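The source may hold more compounds than are shown below. What is called first, only, known or untested is meant among the compounds shown, and "the series" means these compounds.

compound 1 `CCCC(=O)Oc1c(C(C)C)cc2c3c1OC(=O)[C@@]31CCCC(C)(C)[C@@H]1CC2`: 99500 nM
compound 2 `CCCCCCCCCCCCCCCC(=O)Oc1c(C(C)C)cc2c3c1OC(=O)[C@@]31CCCC(C)(C)[C@@H]1CC2`: > 1000000 nM, a limit of the assay

Within the data shown here, in an ADME assay on AGS cells (Homo sapiens) for cytotoxicity, read by neutral red uptake, with a stated time of 24 h (a lower number here means a stronger inhibitor, a higher number a weaker inhibitor), compound 1 gives 99500 nM, the only actual number so far. The entry for compound 2 is a limit, as the limit of > 1000000 nM in this assay, at which 1 of the 2 values shown sits, records.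

Compound 3 `CC(C)c1cc2c3c(c1OC(=O)Cc1c[nH]c4ccccc14)OC(=O)[C@@]31CCCC(C)(C)[C@@H]1CC2` keeps the shared core of compound 1 and carries one change: 1H-indol-3-yl in place of ethyl on a saturated chain carbon bound to a carbonyl carbon.

Among the measured compounds shown here, only one measured step bears on this, an at least 10-fold higher number from compound 1 to compound 2 (1.00 log units; beyond the scatter), and it concerns a different group, so it is a weak guide. On the basis of that step, a much smaller change in the same direction is expected in this assay, possibly none beyond the scatter. The estimated change is a 1.5-fold higher number from compound 1 to compound 3 (0.18 log units; within the scatter). For compound 3 the expected value is 150000 nM, with an estimated range of 50000 nM to 500000 nM.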

Compound 3, half-maximal inhibitory concentration: 85600 nM
The estimate for compound 3 lay 1.8-fold (0.24 log units) above the measured number; measured number inside the range.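

Putting 1H-indol-3-yl in place of ethyl on a saturated chain carbon bound to a carbonyl carbon gives a 1.2-fold lower number from compound 1 to compound 3 (0.07 log units; within the scatter) in this assay, so this place takes a group with two aromatic rings and a hydrogen-bond donor with no readable shift. The earlier step, an at least 10-fold higher number from compound 1 to compound 2 (1.00 log units; beyond the scatter), came with dodecyl, and compound 3 shows that a large shift does not follow from every large group added here. The measurements shown do not explain why dodecyl and 1H-indol-3-yl differ in this way.

Going by these compounds, whether an amine or a carboxylic acid at this place would move the number remains open. So does the question of whether a plain phenyl ring would match 1H-indol-3-yl, and how a chain of a length short of the one in compound 2 would behave.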